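This account rests on a few compounds, and the source may have more. Where it says the series, first, only, none or still open, it means among the compounds named here.

Compound 1 `Cc1ccc2c(c1)N(S(=O)(=O)c1ccc(-c3cnc(C4CC4)o3)cc1)CCCO2` and compound 3 `COc1ccc2c(c1)N(S(=O)(=O)c1ccc(-c3cnc(C4CC4)o3)cc1)CCCO2` share one core. In a functional assay on SK-OV-3 cells (Homo sapiens) for antiproliferative activity, read by MTT assay, with a stated time of 72 h (on this read-out lower numbers stand for stronger inhibition and higher numbers for weaker inhibition), compound 1 gives 34 nM, and in this assay compound 3 gives 53 nM. The change between them is methoxy in place of methyl on an aromatic carbon, and it made a 1.6-fold higher number from compound 1 to compound 3 (0.19 log units; within the scatter). Compound 2 `Cc1ccc2c(c1)OCCCN2S(=O)(=O)c1ccc(-c2cnc(C3CC3)o2)cc1` is built from the same atoms joined differently; the difference between the two cores is not broken down here. In this assay compound 2 gives 179 nM, the highest number of the three measured. Compound 4 `COc1ccc2c(c1)OCCCN2S(=O)(=O)c1ccc(-c2cnc(C3CC3)o2)cc1` is not yet measured. It differs from compound 2 by methoxy in place of methyl on an aromatic carbon, the same change, at the same place, as from compound 1 to compound 3. For compound 4 a step of similar size is expected, a 1.6-fold higher number from compound 2 to compound 4 (0.19 log units; within the scatter), resting on the measured step from compound 1 to compound 3 a 1.6-fold higher number from compound 1 to compound 3 (0.19 log units; within the scatter). Compound 4 is thus expected to give about 280 nM in this assay, estimated between 120 nM and 700 nM.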

Compound 4, half-maximal inhibitory concentration: 185 nM
Compound 4: middle estimate off by 1.5-fold (0.18 log units), on the high side; measured number inside the range.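

Methoxy in place of methyl gives a 1.0-fold higher number from compound 2 to compound 4 (0.01 log units; within the scatter) in this assay, and the two cores can be set side by side: the same change on two cores in this assay, a 1.6-fold higher number (0.19 log units; within the scatter) from compound 1 to compound 3 and a 1.0-fold higher number (0.01 log units; within the scatter) from compound 2 to compound 4, 1.5-fold (0.18 log units) apart, within the scatter of two such steps. In this pair of cores the change therefore carries across, with the step on each core staying within the scatter. Among the compounds shown here, this rests on only two small steps in one cell assay, so it does not show that a change with a larger step would carry across in the same way, and it does not explain the difference between the cores.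

Open, from the compounds shown here alone, is whether other groups at this place, such as an amine, a carboxylic acid or a longer chain, would behave alike on both cores. Also open, going by these compounds, is whether the match holds on any further core.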